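A few compounds are considered here, and "the series" means these few. Any claim that something is new, unique, unknown or untested is made for them only; others in the source may bear on it.

Measured so far in an in vitro assay on 293-EBNA cells for binding affinity to corticotropin-releasing factor receptor 1 (Homo sapiens); on this read-out higher numbers stand for weaker inhibition and lower numbers for stronger inhibition:
compound 1 `Cc1nc(N2CCCCC2)c2nnn(-c3ccc(C(C)C)cc3Br)c2n1` gives 46 nM;
compound 2 `CCC(COC)N(C)c1nc(C)nc2c1nnn2-c1ccc(C(C)C)cc1Br` gives 11.2 nM;
compound 3 `CCC(COC)Nc1nc(C)nc2c1nnn2-c1c(C)cc(C)cc1C` gives 59.4 nM.

Compound 3 has the highest number of the three in this assay: its gap to compound 1 lies within the scatter, its gap to compound 2 beyond it. Compound 4 `CCCC(CCC)Nc1nc(C)nc2c1nnn2-c1c(C)cc(C)cc1C` differs from compound 3 by 1-propylbutyl in place of 1-(methoxymethyl)propyl on a nitrogen on an aromatic ring; the group that leaves carries one hydrogen-bond acceptor, the group that enters none. Within the data shown here, the only measured step at a nitrogen on the core, a 4.1-fold lower number from compound 1 to compound 2 (0.61 log units; beyond the scatter), exchanged a ring for an open chain and does not test this particular exchange. Compound 4 is therefore expected to give roughly 60 nM, between 20 nM and 180 nM, an estimated step of a 1.0-fold higher number from compound 3 to compound 4 (0.00 log units; within the scatter) that stays within the scatter.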

Compound 4, inhibition constant: 4 nM
Beside the measured number, compound 4's estimate is 15-fold (1.18 log units) above it; measured number outside the range, below it.
By their numbers in this assay, from the lowest: compound 4; then compound 2; then compounds 1 and 3 (each within the scatter of the next).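

In this assay, replacing 1-(methoxymethyl)propyl with 1-propylbutyl on a nitrogen on an aromatic ring gives a 15-fold lower number from compound 3 to compound 4 (1.17 log units; beyond the scatter) and shows that this position responds strongly to an exchange between two open chains, which the earlier ring-to-chain step did not test. The entering group carries no hydrogen-bond acceptor, but this one pair cannot separate that difference from the others between the two groups. No evidence bears on the cause of the step.

As far as these compounds go, whether a 1-ethylpropyl or 1-(hydroxymethyl)propyl group would follow the same direction remains open. So does whether this exchange would give a similar step with the aryl group of compound 1 and compound 2.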